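The source may report more compounds than this note shows. Statements on the series, on what has been measured and on what is new or still open speak of the compounds shown alone.

Three compounds have been measured in an ADME assay on MDBK cells (Bos taurus) for cytotoxicity, read by MTT assay, with a stated time of 96 h; a higher number here means that more compound is tolerated, a lower number that less compound is tolerated:

Compound 1 `CC(=O)c1ccc2[nH]c(-c3ccccc3)nc2c1`: > 100000 nM
Compound 2 `CC(=O)c1ccc2[nH]c(-c3ccc(Cl)cc3)nc2c1`: > 100000 nM
Compound 3 `C/C(=N\NC(N)=O)c1ccc2c(c1)nc(-c1ccccc1)n2C1CCCCC1`: > 100000 nM

The value of compound 1 is a limit of this assay, not a number. The value of compound 2 is likewise a limit. The value of compound 3 is a limit as well.

Compound 1 and compound 2 differ by chloro in place of hydrogen on an aromatic carbon. The step that the two limits leave unreadable from compound 1 to compound 2 cannot be sized, since both of its ends sit at the limit of > 100000 nM in this assay, at which 3 of the 3 values shown sit. How the core of compound 3 differs from the core of compound 1 is not broken down here; the two cores differ in more than one place.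

Compound 4 `C/C(=N\NC(N)=O)c1ccc2c(c1)nc(-c1ccc(Cl)cc1)n2C1CCCCC1` is not yet measured. It differs from compound 3 by chloro in place of hydrogen on an aromatic carbon, and the place is the same as in the change from compound 1 to compound 2, so this is the same change made a second time. For the step from compound 3 to compound 4 the expectation is a step that the limit leaves unreadable from compound 3 to compound 4, set beside the earlier step that could not be read. This rests on compound 3 sitting at > 100000 nM and on all three measured values sitting at the limit of > 100000 nM in this assay, at which 3 of the 3 values shown sit, with no sign so far that the chloro moves a compound off that limit. Compound 4 is therefore expected at 150000 nM, with a range from 70000 nM to 400000 nM, and most likely to be reported only as a limit again.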

Compound 4, half-maximal cytotoxic concentration: > 100000 nM
Compound 4 ended at the assay's limit; the forecaster's own chance of this, stated with the estimate: 85%; the middle value does not contradict the limit.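

In this assay, no size can be read for the step from compound 3 to compound 4, the change from phenyl to 4-chlorophenyl, as both of its ends are limits and not numbers: the limit of > 100000 nM in this assay, at which 4 of the 4 values shown sit.

The compounds shown leave open how much of compound 3 or compound 4 the cells tolerate, and whether the chloro makes any difference to that.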